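A few compounds are considered here, and "the series" means these few. Any claim that something is new, unique, unknown or untested is made for them only; others in the source may bear on it.

Of the compounds shown here, three that share one core have been read in a physicochemical assay for lipophilicity; on this read-out lower numbers stand for lower lipophilicity and higher numbers for higher lipophilicity. There, compound 1 `Cc1cn(C2CC(N=[N+]=[N-])C(COC(=O)OCCCCO)O2)c(=O)[nH]c1=O` gives -0.68, compound 3 `Cc1cn(C2CC(N=[N+]=[N-])C(COC(=O)NCCCC(=O)O)O2)c(=O)[nH]c1=O` gives -0.81 and compound 2 `Cc1cn(C2CC(N=[N+]=[N-])C(COC(=O)OCCCCCCO)O2)c(=O)[nH]c1=O` gives 0.08. Compound 2 stands highest of the three, as the steps show: a number 0.76 log units higher from compound 1 to compound 2 (beyond the scatter), and a number 0.89 log units lower from compound 2 to compound 3 (beyond the scatter).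

Compound 4 `Cc1cn(C2CC(N=[N+]=[N-])C(COC(=O)OCCO)O2)c(=O)[nH]c1=O` has not yet been measured. It departs from compound 2 by one change: hydroxy in place of 4-hydroxybutyl on a saturated chain carbon, two bonds along the chain from an oxygen next to a carbonyl group. In words, hydroxy stands in place of 4-hydroxybutyl on a saturated chain carbon, two bonds along the chain from an oxygen next to a carbonyl group.

Within the data shown here, the closest precedent is a number 0.76 log units higher from compound 1 to compound 2 (beyond the scatter), where 2-hydroxyethyl replaces hydroxy further out on the same chain. The new change runs the opposite way and removes the larger 4-hydroxybutyl, so a downward step larger than that precedent is expected, well beyond the scatter. The step of a number 0.13 log units lower from compound 1 to compound 3 (within the scatter) and the step of a number 0.89 log units lower from compound 2 to compound 3 (beyond the scatter) replace the whole group on the carbonyl carbon and say little here. Among the measured compounds shown here, with only one chain step to go on, the extrapolation is uncertain. The expected change is a number 1.38 log units lower from compound 2 to compound 4 (beyond the scatter). For compound 4 the estimated value is -1.3, with an expected range from -1.7 to -0.95.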

Compound 4, partition coefficient: -1.2
The estimate for compound 4 lay 0.10 log units below the measured number; measured number inside the range.
By their numbers in this assay, from the lowest: compound 4; then compounds 3 and 1 (each within the scatter of the next); then compound 2.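

In this assay, the hydroxy-ended chain on the carbonyl carbon can now be read at three lengths, and compounds 4, 1 and 2 rise in that order. Compound 3 stands outside this series, as it carries a different group. Hydroxy in place of 4-hydroxybutyl gives a number 1.28 log units lower from compound 2 to compound 4 (beyond the scatter), while the smaller cut, hydroxy in place of 2-hydroxyethyl, still gives a number 0.52 log units lower from compound 1 to compound 4 (beyond the scatter), so the shortening continues to register below the 4-hydroxybutoxy chain of compound 1. The 2-hydroxyethoxy group also separates from (3-carboxypropyl)amino, with a number 0.39 log units lower from compound 3 to compound 4 (beyond the scatter), whereas the 4-hydroxybutoxy group of compound 1 lay within the scatter of that group.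

Nothing shown here accounts for these steps. From the compounds shown here alone, it remains open whether the same direction would hold for a longer chain than (6-hydroxyhexyl)oxy, and whether it would survive with an amine or a carboxylic acid in place of the hydroxy at the end of the 2-hydroxyethoxy chain.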